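From 1H-indol-3-yl to 3-methylthiophen-2-yl in compound 3

The source may hold more compounds than are shown below. What is called first, only, known or untested is meant among the compounds shown, and "the series" means these compounds.

Measured so far in a functional assay on DU-145 cells (Homo sapiens) for inhibition, read by trypan blue exclusion, with a stated time of 96 h (on this read-out lower numbers stand for stronger inhibition of growth and higher numbers for weaker inhibition of growth), for two compounds
- Compound 1 `Cc1ccc(S(=O)(=O)/C(=C/c2sccc2C)C(=O)c2ccc(Cl)cc2)cc1` gives 10000 nM in this series
- Compound 2 `Cc1ccc(S/C(=C/c2c[nH]c3ccccc23)C(=O)c2ccc(Br)cc2)cc1` gives 10000 nM in this series

Compound 2 stands level with compound 1, within the scatter. For the measured compounds named here, compound 3 `Cc1ccc(S/C(=C/c2sccc2C)C(=O)c2ccc(Br)cc2)cc1` follows from compound 2 with 3-methylthiophen-2-yl in place of 1H-indol-3-yl on a double-bonded chain carbon bound to a double-bonded chain carbon as the only change. Going by the values given here, no measured pair differs in one place, so no step gauges this change directly. Compound 1 also bears 3-methylthiophen-2-yl and gives 10000 nM in this assay but differs from compound 3 elsewhere as well. No shift beyond the scatter is expected, and the estimated change is a 1.4-fold lower number from compound 2 to compound 3 (0.15 log units; within the scatter) on present evidence. The estimate for compound 3 is 7000 nM with an expected range from 2000 nM to 15000 nM in this assay for now.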

Compound 3, concentration for 50% growth inhibition: 50000 nM
Compound 3: middle estimate off by 7.1-fold (0.85 log units), on the low side; the measured number lies above the stated range.
By their numbers in this assay, from the lowest: compounds 1 and 2 (each within the scatter of the next); then compound 3.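

In this assay, for the compounds shown here, the place on a double-bonded chain carbon bound to a double-bonded chain carbon is not indifferent to the group it carries: 3-methylthiophen-2-yl in place of 1H-indol-3-yl gives a 5.0-fold higher number from compound 2 to compound 3 (0.70 log units; beyond the scatter) as the first single change that can be read. Within this pair, growth inhibition is weaker with 3-methylthiophen-2-yl, and the change also removes the hydrogen-bond donor and the six-membered aromatic ring counted for 1H-indol-3-yl, so this one step cannot separate those features. Nothing measured on these compounds accounts for the step.

The compounds shown leave open whether a phenyl or a pyridinyl group at this place would behave like 1H-indol-3-yl or like 3-methylthiophen-2-yl. They also leave open whether the same change would give a step of similar size on the core of compound 1.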